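Coumarin-like compounds and monoamine oxidase A inhibition

A few compounds are considered here, and "the series" means these few. Any claim that something is new, unique, unknown or untested is made for them only; others in the source may bear on it.

Measured compounds:
Compound 1 `O=C(O)COc1cc(=O)oc2cc(OCc3cccc(Cl)c3)ccc12`: 0%
Compound 2 `O=c1cc(Oc2ccccc2)c2ccc(OCc3cccc(Cl)c3)cc2o1`: 0%

Two compounds sharing a bicyclic core carrying a chlorobenzyloxy group have been tested in an assay on isolated protein (strain Sprague-Dawley) for inhibition of Amine oxidase [flavin-containing] A (Rattus norvegicus), read by spectrophotometry, with a stated time of 5 min, tested at 10 uM; on this read-out lower numbers stand for less inhibition and higher numbers for more inhibition at the one concentration tested (going by the name of the read-out). Compound 1 gives 0% in this assay, and compound 2 gives 0%. Among the compounds with values here, the one step between them, no change at the digits printed from compound 1 to compound 2 (within the scatter), replaces a carboxymethyl with a phenyl on an oxygen attached to the core and leaves the read-out where it was. Compound 2 therefore stands level with compound 1; neither shows measurable inhibition at the tested concentration.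

Compound 3 `CC(=O)c1cc(=O)oc2cc(OCc3cccc(Cl)c3)ccc12` has not been measured. It differs from compound 2 in one place: acetyl in place of phenoxy on an aromatic carbon. Within the data shown here, no measured step involves an acetyl group, so the only guide is that both measured compounds, with quite different groups at this position, sit at the floor of the read-out. On that basis the change is expected to bring no step beyond the scatter, and a number 3 percentage points higher from compound 2 to compound 3 (within the scatter) is estimated accordingly. Compound 3 is expected to give about 3% in this assay, with a range from 0% to 15%.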

Compound 3, a percentage reported as inhibition, at one concentration (the size of the read-out at that concentration, not a potency): 0%
For compound 3 the middle estimate is 3 percentage points above the measured one; the measured number falls inside the stated range.
By their numbers in this assay, from the lowest: compounds 1, 2 and 3 (each within the scatter of the next).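

In this assay, acetyl in place of phenoxy brings no change at the digits printed from compound 2 to compound 3 (within the scatter), which extends the earlier picture to a much smaller group with no ring of its own, joined to the aromatic carbon through carbon rather than through oxygen. Acetyl in place of carboxymethoxy likewise brings no change at the digits printed from compound 1 to compound 3 (within the scatter), so the three groups tried at this position, one with a six-membered aromatic ring, one with an acid side chain and one with neither, cannot be told apart at the one concentration tested, and all three compounds remain without measurable inhibition. Nothing on hand explains why this position gives no response in any of the three compounds.

With every value at the bottom of the read-out, these compounds cannot show whether any of the three groups is better or worse than another, only that none of them brings measurable inhibition with the chlorobenzyloxy group in place. On these data alone, it remains open whether an amine, a hydroxyl or a longer carbon chain at this position would give any inhibition, and whether a different group in place of the 3-chlorobenzyloxy would change the result.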